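A larger group on the ring nitrogen of compound 3

The compounds below may be only part of what the source reports. "The series", "measured", "known", "first", "only" and "open" are said of these compounds alone.

Compound 1 `O=C(Nc1ncc(Cc2ccc(Br)cc2)s1)c1ccc2ccccc2c1`: in an ADME assay on HepG2 2.2.15 cells (Homo sapiens) for cytotoxicity (on this read-out higher numbers stand for lower toxicity in this test and lower numbers for higher toxicity in this test), compound 1 gives > 50000 nM, which is a limit of the assay rather than a number.
Compound 2 `CC(C)(C)OC(=O)Nc1ncc(C(Oc2ccc(F)c(Cl)c2)c2ccc(Cl)cc2)s1`: in this assay compound 2 gives > 50000 nM, again a limit of the assay.
Compound 3 `CCCCCC(=O)Nc1ncc(C(Oc2ccc3cc(Br)ccc3c2)c2ccc(Cl)cc2)s1`: in this assay compound 3 gives > 50000 nM, also a limit of the assay.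

Compound 3 therefore stands where every measured compound here stands: at the limit, with no numerical value of its own, and the other two values shown are limits as well (the limit of > 50000 nM in this assay, at which 3 of the 3 values shown sit). No pair of these compounds differs in just one place, so no measured step exists to lean on.

Compound 4 `O=S(=O)(Nc1ncc(C(Oc2ccc3cc(Br)ccc3c2)c2ccc(Cl)cc2)s1)c1ccc2c(c1)CCO2` is the untested compound. It differs from compound 3 by a group of 12 heavy atoms (8 carbon, 3 oxygen, 1 sulfur; one five-membered non-aromatic ring with 1 hetero atom, one six-membered aromatic ring of carbon only) in place of a group of 7 heavy atoms (6 carbon, 1 oxygen; no ring), on a nitrogen on an aromatic ring.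

With nothing measured beyond the limit, the expected outcome is no change beyond the usual scatter in this assay; the step from compound 3 to compound 4 is estimated as a step that the limit leaves unreadable from compound 3 to compound 4. For compound 4 the expected value in this assay is 60000 nM, with a likely range from 20000 nM to 150000 nM, and most probably the assay will again report only a limit.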

Compound 4, half-maximal cytotoxic concentration: > 50000 nM
Compound 4 gave a limit, no number; the forecaster's own chance of this, stated with the estimate: 75%; the middle value is on the limit's open side.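

The step from compound 3 to compound 4 cannot be read, since both compounds give only a limit and no number: the limit of > 50000 nM in this assay, at which 4 of the 4 values shown sit.

The compounds shown leave open what concentration of any of them would harm the cells in this assay, and whether swapping the group on the nitrogen changes that.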